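The source may hold more compounds than are shown below. What is called first, only, known or untested is meant among the compounds shown, and "the series" means these compounds.

Measured compounds:
compound 1, `O=C(Nc1nn(-c2ccccc2)c(=O)c2ccccc12)c1ccccc1`, 44%
compound 2, `COc1ccc(OC)c(NC(=O)Nc2nn(-c3ccccc3)c(=O)c3ccccc23)c1`, 0%

Both compounds were tested in an assay on CHO cells for displacement of a labelled ligand from adenosine receptor A1 (Homo sapiens), tested at 10 uM; on this read-out higher numbers stand for more inhibition at the one concentration tested (going by the name of the read-out) and lower numbers for less inhibition. Compound 1 gives 44% in this assay, while compound 2 gives 0%, the lowest of the two numbers; the gap between them is beyond the usual scatter. For the measured compounds named here, no pair of compounds here differs in one place only, so no single structural step can be read from the measured values.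

Compound 3, `COc1ccc(NC(=O)Nc2nn(-c3ccccc3)c(=O)c3ccccc23)cc1`, has not yet been tested in this assay. It differs from compound 2 by 4-methoxyphenyl in place of 2,5-dimethoxyphenyl on an amide-type nitrogen. Since nothing measured here shows what this change does, only a modest step can be expected, if any, and the nearest comparison is compound 2 with its 0%. The step of a number 12 percentage points higher from compound 2 to compound 3 (beyond the scatter) is expected to be small and upward, possibly within the scatter. Compound 3 is estimated at 12%, within the range 0% to 35%.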

Compound 3, a percentage reported as inhibition, at one concentration (the size of the read-out at that concentration, not a potency): 4%
Compound 3: middle estimate off by 8 percentage points, on the high side; the range from low to high includes it.
By their numbers in this assay, from the lowest: compounds 2 and 3 (each within the scatter of the next); then compound 1.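

On the amide-type nitrogen, 4-methoxyphenyl in place of 2,5-dimethoxyphenyl gives a number 4 percentage points higher from compound 2 to compound 3 (within the scatter) in this assay, so exchanging these two aryl groups makes no readable difference on this read-out. The large step lies on the carbonyl carbon, where (4-methoxyphenyl)amino in place of phenyl gives a number 40 percentage points lower from compound 1 to compound 3 (beyond the scatter), showing that the low numbers are not confined to the 2,5-dimethoxyphenyl group of compound 2. No supporting measurement here explains either step.

That large step swaps in the amino link and the methoxy-bearing ring together, so the compounds shown cannot say which part accounts for it. As far as these compounds go, a plain phenylamino group on the carbonyl carbon would separate the two, and whether an amine or a carboxylic acid on the aryl ring would change the number also remains open.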